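This account rests on a few compounds, and the source may have more. Where it says the series, first, only, none or still open, it means among the compounds named here.

Working notes on the series.

Of the compounds shown here, three have been measured in a functional assay on MOLT-4 cells (Homo sapiens) for cytotoxicity, read by sulforhodamine B assay, with a stated time of 48 h; on this read-out higher numbers stand for lower toxicity in this test and lower numbers for higher toxicity in this test. Compound 1 `ClCc1cccc(Cn2cnc3ncnc(Cl)c32)c1` gives 81300 nM. Compound 2 `ClCc1cccc(Cn2cnc3c(Cl)ncnc32)c1` gives 89100 nM, a number that falls within the scatter of compound 1. Compound 3 `ClCc1ccccc1Cn1cnc2ncnc(Cl)c21` gives 16600 nM, a lower number than compound 1 by a gap that lies beyond the scatter. Compound 1 thus stands second highest of the three numbers, close to compound 2 and well apart from compound 3. For the measured compounds named here, none of the measured pairs differs in one place only, so no single step has been quantified in this assay.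

Compound 4 `ClCc1cccc(Cn2cnc3nc(Cl)nc(Cl)c32)c1` has not been measured. It differs from compound 1 by chloro in place of hydrogen on an aromatic carbon. Going by the values given here, nothing among the measured compounds shows what a change of this kind does in this assay. The step from compound 1 to compound 4 is therefore expected to be small, a 1.3-fold lower number from compound 1 to compound 4 (0.10 log units; within the scatter), with no direction that can be argued from the data and possibly none beyond the scatter. Compound 4 is estimated at 65000 nM, with a range from 20000 nM to 200000 nM.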

Compound 4, concentration lethal to 50% of the cells: 5010 nM
The estimate for compound 4 lay 13-fold (1.11 log units) above the measured number, and the stated range ends above it.
By their numbers in this assay, from the lowest: compound 4; then compound 3; then compounds 1 and 2 (each within the scatter of the next).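

In this assay, for the compounds shown here, chloro in place of hydrogen on an aromatic carbon gives the first single change with a measured size, and the step of a 16-fold lower number from compound 1 to compound 4 (1.21 log units; beyond the scatter) is large and lies beyond the scatter. Going by these compounds alone, the position between two ring nitrogen atoms is therefore not silent: one added chlorine here moves the number toward higher toxicity in this test, which the earlier compounds could not show because none of them formed a pair differing in one place. No available evidence bears on the reason for this step.

On these data alone, whether the step belongs to chloro itself or would also appear with an amine, a methoxy group or fluoro at this position remains open. Also open, as far as these compounds go, is whether chloro here gives a step of similar size on the cores of compound 2 and compound 3.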